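The source may report more compounds than this note shows. Statements on the series, on what has been measured and on what is new or still open speak of the compounds shown alone.

Compound 1 `O=c1[nH]c(=O)n(Cc2ccccc2)cc1Nc1ccccc1` was tested in an ADME assay on CEM-SS cells (Homo sapiens) for cytotoxicity, read by XTT assay; on this read-out lower numbers stand for higher toxicity in this test and higher numbers for lower toxicity in this test. In this assay compound 1 gives only a limit of the test, > 100000 nM. Compound 2 `Cc1ccccc1Cn1cc(Nc2ccccc2)c(=O)[nH]c1=O` differs from compound 1 by a methyl in place of hydrogen on an aromatic carbon. In this assay compound 2 likewise gives only a limit, > 100000 nM. The step that the two limits leave unreadable from compound 1 to compound 2 therefore cannot be read in size. Compound 3 `Cc1ccc(Nc2cn(Cc3ccc(Cl)cc3Cl)c(=O)[nH]c2=O)cc1` has no result in this assay, "not determined" (no result reported). The compound not yet measured is compound 4 `O=c1[nH]c(=O)n(Cc2cccc(Oc3ccccc3)c2)cc1Nc1ccccc1`; it differs from compound 1 by phenoxy in place of hydrogen on an aromatic carbon. Among the compounds with values here, the single measured step, the one between compound 1 and compound 2, is the only comparison that bears on this change, and it sets no size at all; what the data do show is the limit of > 100000 nM in this assay, at which 2 of the 3 values shown sit. With both measured neighbours resting at that limit, nothing points to a change beyond the scatter. For compound 4 the expected step is a step that the limit leaves unreadable from compound 1 to compound 4. The estimate for compound 4 is 150000 nM, between 40000 nM and 500000 nM, and another limit is the likely outcome.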

Compound 4, half-maximal cytotoxic concentration: > 100000 nM
Compound 4: a limit, no number (the forecaster's own chance of this, stated with the estimate: 75%); the middle value does not contradict the limit.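

In this assay compound 4 gives only a limit, as compound 1 does, so no size can be read for the step between compound 1 and compound 4. The compounds shown leave open what concentration of compound 1, compound 2 or compound 4 would prove toxic, and whether phenoxy alters it.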